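The compounds below may be only part of what the source reports. "The series", "measured", "known", "first", "only" and "open" are said of these compounds alone.

Measured so far in a functional assay on thoracic aorta (Rattus norvegicus, strain Wistar), with a stated time of 15 min; on this read-out lower numbers stand for an effect already at smaller amounts and higher numbers for an effect only at larger amounts of compound:
Compound 1 `CCOc1ccc(F)cc1C(C)NC(=O)NS(=O)(=O)c1ccc(C)cc1`: > 300000 nM
Compound 2 `COc1ccc(Br)cc1C(C)NC(=O)NS(=O)(=O)c1ccc(C)cc1`: > 300000 nM
Compound 3 `COc1ccc(Br)cc1C(C)NC(=O)N(C)S(=O)(=O)c1ccc(C)cc1`: 19100 nM

Compound 2 gives no number, only a limit of the assay: > 300000 nM. Compound 1 also gives only a limit: > 300000 nM. Within the data shown here, compound 3 is the only compound with a measured number: 19100 nM.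

The next compound, compound 4 `COc1ccc(F)cc1C(C)NC(=O)NS(=O)(=O)c1ccc(C)cc1`, changes one place in compound 2: fluoro in place of bromo on an aromatic carbon. Among the measured compounds shown here, the one measured step, an at least 15-fold lower number from compound 2 to compound 3 (1.19 log units; beyond the scatter), is large, but it is methyl in place of hydrogen on an amide-type nitrogen, so it bears on the fluoro for bromo change only indirectly. Compound 4 keeps the amide hydrogen, as do compound 1 and compound 2. With those two compounds in view, and because of the limit of > 300000 nM in this assay, at which 2 of the 3 values shown sit, no step beyond the scatter is expected in this assay, and a limit is the likeliest report.

The expected change is a number no higher from compound 2 to compound 4 (the limit leaves the size open). For compound 4 the estimated value is 300000 nM, with an expected range from 120000 nM to 600000 nM.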

Compound 4, half-maximal effective concentration: > 300000 nM
Compound 4 gave a limit, no number; the forecaster's own chance of this, stated with the estimate: 85%; the middle value lies on the limit itself.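

Compound 4 gives only a limit of the assay, > 300000 nM. Compound 1 and compound 2 also give only limits, so neither step to compound 4 can be read: the limit of > 300000 nM in this assay, at which 3 of the 4 values shown sit.

Still open, going by these compounds, is whether fluoro in place of bromo changes the read-out at all, with the amide hydrogen present or with the methyl of compound 3 on that nitrogen.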